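Fluoro in place of hydrogen on the amide-bearing ring

The source may report more compounds than this note shows. Statements on the series, on what has been measured and on what is new or still open speak of the compounds shown alone.

Measured so far:
compound 1 `O=C(Nc1ccc(Oc2ccnc3[nH]ccc23)cc1)c1cc(-c2ccc(C(F)(F)F)cc2)ncn1` — 9380 nM in a functional assay on A549 cells (Homo sapiens) for cytotoxicity, read by MTT assay, with a stated time of 72 h; a higher number here means a weaker inhibitor, a lower number a stronger inhibitor
compound 2 `Cc1ccc(-c2cc(C(=O)Nc3ccc(Oc4ccnc5[nH]ccc45)cc3)ncn2)cc1` — 5410 nM in this assay

Among the compounds with values here, compound 2 gives the lowest number of the two, with only compound 1 near it; the only step known, a 1.7-fold lower number from compound 1 to compound 2 (0.24 log units; within the scatter), concerns a change on the other terminal ring. Compound 3 `Cc1ccc(-c2cc(C(=O)Nc3ccc(Oc4ccnc5[nH]ccc45)c(F)c3)ncn2)cc1` differs from compound 2 by fluoro in place of hydrogen on an aromatic carbon. Within the data shown here, no measured step bears on this change, so no direction can be drawn from the numbers; a step of a 1.1-fold lower number from compound 2 to compound 3 (0.03 log units; within the scatter) is expected, staying within the scatter. Compound 3 is therefore estimated at 5000 nM in this assay, in the range 1500 nM to 16000 nM.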

Compound 3, half-maximal inhibitory concentration: 8600 nM
Compound 3: the middle estimate sits 1.7-fold (0.24 log units) below what was measured; the measured number falls inside the stated range.
By their numbers in this assay, from the lowest: compounds 2, 3 and 1 (each within the scatter of the next).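

Fluoro in place of hydrogen on this aromatic carbon, ortho to a large group and meta to a large group, gives a 1.6-fold higher number from compound 2 to compound 3 (0.20 log units; within the scatter) in this assay, so the change produces no step beyond the scatter. Within the data shown here, the earlier step concerned only the other terminal ring, and this is the first reading on the amide-bearing ring. No evidence bearing on this result is available.

Open: whether chloro, methoxy or an amine at this carbon would give a step beyond the scatter, and whether fluoro on the other carbons of this ring would read alike.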